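Compound 4: hydrogen in place of chloro on compound 3

This account rests on a few compounds, and the source may have more. Where it says the series, first, only, none or still open, it means among the compounds named here.

Compound 3 `COc1cc(Cl)cc(-c2nn(-c3cccc(NC(=O)Nc4ccc(Cl)c(C(F)(F)F)c4)c3)cc2-c2ccncc2)c1` stands second highest of the three numbers in a functional assay on NCI-H460 cells (Homo sapiens) for inhibition, read by sulforhodamine B assay, with a stated time of 48 h, tested at 10 uM (on this read-out lower numbers stand for a stronger effect and higher numbers for a weaker effect at the one concentration tested), all within the scatter of one another: compound 3 gives 2.76%, compound 1 `O=C(Nc1cccc(-n2cc(-c3ccncc3)c(-c3cc(O)cc(Cl)c3)n2)c1)Nc1ccc(Cl)c(C(F)(F)F)c1` gives 3.75%, and compound 2 `O=C(Nc1cccc(-n2cc(-c3ccncc3)c(-c3cc(O)cc(Cl)c3)n2)c1)Nc1ccc(Cl)c(Cl)c1` gives 0.21%. Compound 4 `COc1cc(Cl)cc(-c2nn(-c3cccc(NC(=O)Nc4cccc(C(F)(F)F)c4)c3)cc2-c2ccncc2)c1` differs from compound 3 in one place: hydrogen in place of chloro on an aromatic carbon. Neither measured step touches that place. The step of a number 3.5 percentage points lower from compound 1 to compound 2 (within the scatter) exchanges trifluoromethyl for chloro, and the step of a number 1 percentage points lower from compound 1 to compound 3 (within the scatter) puts methyl on the oxygen; both stay within the scatter. Within the data shown here, no step removes a chloro, so the expectation rests on the narrow spread of the three numbers, with a step of a number 3.2 percentage points higher from compound 3 to compound 4 (within the scatter) expected to stay within the scatter. Compound 4 is therefore estimated at 6%, with a range from 0% to 25%.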

Compound 4, a percentage reported as activity, at one concentration (the size of the read-out at that concentration, not a potency): -6.11%
The estimate for compound 4 lay 12.1 percentage points above the measured number, and the stated range ends above it.
By their numbers in this assay, from the lowest: compounds 4, 2, 3 and 1 (each within the scatter of the next).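

In this assay, the exchange of chloro for hydrogen on the 4-chloro-3-(trifluoromethyl)phenyl group gives a number 8.9 percentage points lower from compound 3 to compound 4 (within the scatter), so this read-out does not separate chloro from hydrogen at this position, ortho to a trifluoromethyl group. No measurement available here bears on this result. Going by these compounds, the read-out at one concentration gives no potency for compound 3 or compound 4, so any difference in potency between them remains open. Also open, on these data alone, is whether an amine or a carboxylic acid at this position would stay within the scatter of compound 4.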